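Branching at the indole nitrogen substituent: compound 4

A few compounds are considered here, and "the series" means these few. Any claim that something is new, unique, unknown or untested is made for them only; others in the source may bear on it.

Measured compounds:
compound 1 `CCCCn1ccc2cc(/C(C)=C/C(=O)Nc3ccccc3OCCCC(=O)O)ccc21` — 43 nM
compound 2 `CCCCC(CCCC)n1ccc2cc(/C(C)=C/C(=O)Nc3ccccc3OCCCC(=O)O)ccc21` — 21 nM
compound 3 `C/C(=C\C(=O)Nc1ccccc1OCCCC(=O)O)c1ccc2c(ccn2Cc2cccc(C)c2)c1` — 250 nM

All three numbers come from an assay on Prostate gland for inhibition of steroid 5-alpha-reductase (Rattus norvegicus); on this read-out lower numbers stand for stronger inhibition and higher numbers for weaker inhibition. Compound 3 stands highest of the three, with the step of a 5.8-fold higher number from compound 1 to compound 3 (0.76 log units; beyond the scatter) and the larger step of a 12-fold higher number from compound 2 to compound 3 (1.08 log units; beyond the scatter). Within the alkyl pair, a 2.0-fold lower number from compound 1 to compound 2 (0.31 log units; beyond the scatter) shows a modest gain on moving to a branched chain attached at the aromatic nitrogen.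

Compound 4 `C/C(=C\C(=O)Nc1ccccc1OCCCC(=O)O)c1ccc2c(ccn2C(C)c2ccccc2)c1` keeps the same atoms as compound 3 but rearranged: 1-phenylethyl in place of 3-methylbenzyl on an aromatic nitrogen. The change moves a methyl from the phenyl ring onto the carbon bound to the aromatic nitrogen, so the substituent becomes branched at that carbon, as in compound 2. Among the measured compounds shown here, the only step bearing directly on branching at that position is the modest one from compound 1 to compound 2; the aryl-for-alkyl steps involving compound 3 are larger but do not address this rearrangement. A modest improvement, of the order seen in that alkyl step, is therefore expected, with a fair chance that it stays within the scatter. For compound 4 the expected step is a 1.7-fold lower number from compound 3 to compound 4 (0.22 log units; within the scatter), and the estimated value for compound 4 in this assay is 150 nM, in the range 60 nM to 400 nM.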

Compound 4, half-maximal inhibitory concentration: 19 nM
Compound 4: the middle estimate sits 7.9-fold (0.90 log units) above what was measured; the whole stated range lies above it.
By their numbers in this assay, from the lowest: compounds 4 and 2 (each within the scatter of the next); then compound 1; then compound 3.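

In this assay, moving the methyl from the phenyl ring onto the carbon bound to the aromatic nitrogen gives a 13-fold lower number from compound 3 to compound 4 (1.12 log units; beyond the scatter), a far larger step than the branching step among the alkyl compounds, a 2.0-fold lower number from compound 1 to compound 2 (0.31 log units; beyond the scatter). A phenyl ring on that carbon is compatible with low numbers: 1-phenylethyl gives a 2.3-fold lower number from compound 1 to compound 4 (0.35 log units; beyond the scatter), while a 1.1-fold lower number from compound 2 to compound 4 (0.04 log units; within the scatter) leaves it indistinguishable from 1-butylpentyl, so the two substituents branched at that carbon share the low end of the series. No available evidence accounts for the size of the step.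

This one rearrangement removes the ring methyl and creates the branch together, so unsubstituted benzyl would be needed to separate the two contributions. Also open, as far as these compounds go, are the two separate mirror-image forms of 1-phenylethyl and whether a larger branch such as 1-phenylpropyl is tolerated.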